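Aryl group change on the ring amine: working notes

The compounds below may be only part of what the source reports. "The series", "measured", "known", "first", "only" and "open" are said of these compounds alone.

Compound 1 `C/C1=C\CC[C@@]2(C)O[C@@H]2[C@H]2OC(=O)[C@@H](CN3CCN(c4ccccc4)CC3)[C@@H]2C[C@H]1O`: 5000 nM
Compound 2 `C/C1=C\CC[C@@]2(C)O[C@@H]2[C@H]2OC(=O)[C@@H](CN3CCN(c4ccccc4F)CC3)[C@@H]2C[C@H]1O`: 6000 nM

In a functional assay on Glioma cells (Homo sapiens) for inhibition, read by MTT assay, with a stated time of 72 h (a higher number here means a weaker inhibitor, a lower number a stronger inhibitor), compound 2 gives 6000 nM, within the scatter of compound 1 at 5000 nM. Compound 3 `COc1ccc(N2CCN(C[C@@H]3C(=O)O[C@H]4[C@H]3C[C@@H](O)/C(C)=C/CC[C@@]3(C)O[C@H]43)CC2)cc1` has 4-methoxyphenyl in place of 2-fluorophenyl on an amine nitrogen in a ring. Within the data shown here, the only measured step on this aryl group is a 1.2-fold higher number from compound 1 to compound 2 (0.08 log units; within the scatter), a fluoro in place of hydrogen on an aromatic carbon. Among the measured compounds shown here, no measured step covers a methoxy group, so no change beyond the scatter is expected. The expected step is a 1.2-fold lower number from compound 2 to compound 3 (0.08 log units; within the scatter). For compound 3 the estimated value is 5000 nM, with an expected range of 2000 nM to 12000 nM.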

Compound 3, half-maximal inhibitory concentration: 18000 nM
Estimate against measurement, compound 3: 3.6-fold (0.56 log units) below; the measured number lies above the stated range.
By their numbers in this assay, from the lowest: compounds 1 and 2 (each within the scatter of the next); then compound 3.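

In this assay, this aryl group on the ring amine proves sensitive to substitution: adding methoxy gives a 3.6-fold higher number from compound 1 to compound 3 (0.56 log units; beyond the scatter), whereas the earlier fluoro step stayed within the scatter. Exchanging 2-fluorophenyl for 4-methoxyphenyl likewise gives a 3.0-fold higher number from compound 2 to compound 3 (0.48 log units; beyond the scatter), so the position does not tolerate every substituent equally. Nothing available bears on the reason for these steps.

Still open, from the compounds shown here alone, is whether the methoxy group itself or its place on the aryl ring accounts for the loss. Going by these compounds, how a hydroxy or dimethylamino group would read here also remains open.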